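A Bulkier Side Chain on the Core of Compound 1

A few compounds are considered here, and "the series" means these few. Any claim that something is new, unique, unknown or untested is made for them only; others in the source may bear on it.

Measured so far in a functional assay on the whole organism (Tail, strain ICR) with Mus musculus as the target, in the tail flick test, with a stated time of 120 min, at a dose of 25 umol/kg by the oral route; on this read-out higher numbers stand for a stronger effect at the one dose given and lower numbers for a weaker effect:
compound 1 `C[C@H](NC(=O)CN(c1ncnc2c1ncn2C1CCCCO1)C1CC1)C(=O)OCc1ccccc1`: 25.3%
compound 2 `NC(=O)C[C@H](NC(=O)CN(c1nc(Cl)nc2[nH]cnc12)C1CC1)C(=O)OCc1ccccc1`: 15.1%

Compound 1 holds the higher of the two numbers shown; compound 2 sits lower, and the gap between them lies beyond the usual scatter. Among the compounds with values here, the two compounds differ in more than one place, so their pair says only what the two values show and gives no single-change step to build on.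

Compound 3 `CC(C)C[C@H](NC(=O)CN(c1ncnc2c1ncn2C1CCCCO1)C1CC1)C(=O)OCc1ccccc1` has not yet been measured. It departs from compound 1 in one place: isopropyl in place of hydrogen on a saturated chain carbon, two bonds along the chain from an amide-type nitrogen and a carbonyl carbon. Read one bond further out, the same difference is methyl to isobutyl, a change that adds a small saturated branch on the chain and leaves the rest of compound 1 untouched.

Within the data shown here, with no single-change pair measured in this assay, the size of this step rests on the change alone. A small branch of this kind is expected to move the number only slightly, in either direction, and most likely not beyond the scatter. The step of a number 2.7 percentage points higher from compound 1 to compound 3 (within the scatter) is thus expected to be small. For compound 3 the estimate is 28%, within a range from 10% to 48%.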

Compound 3, a percentage reported as activity, at one dose (the size of the read-out at that dose, not a potency): 12.8%
Beside the measured number, compound 3's estimate is 15.2 percentage points above it; low and high end bracket the measured number.
By their numbers in this assay, from the lowest: compounds 3 and 2 (each within the scatter of the next); then compound 1.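

In this assay, within the data shown here, the exchange of hydrogen for isopropyl on a saturated chain carbon, two bonds along the chain from an amide-type nitrogen and a carbonyl carbon, gives the first single-change step: a number 12.5 percentage points lower from compound 1 to compound 3 (beyond the scatter). Read one bond further out as methyl to isobutyl, it shows that this position is not indifferent to a small saturated branch, since this one change, with the shared core and the rest of compound 1 left as they are, lowers the effect at the one dose given by more than the usual scatter. Nothing measured here says what lies behind this drop.

The compounds shown leave open whether the loss follows the length of the chain or the branch itself, which an ethyl group or an unbranched butyl chain in the same place could help to separate. They also leave open whether the lower number holds for every kind of group here, as a hydroxymethyl group, a carboxylic acid or an amine might show a different step from compound 1.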